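A Cyano Group Replaces Fluorine on the Arylsulfonyl

The compounds below may be only part of what the source reports. "The series", "measured", "known", "first", "only" and "open" are said of these compounds alone.

Compound 2 `CN1CCN(c2ccc(C3=NN(S(=O)(=O)c4ccc(F)cc4)C(c4ccc(N(C)C)cc4)C3)cc2)CC1` stands highest of the two compounds measured in a functional assay on HCC1806 cells (Homo sapiens) for inhibition, read by sulforhodamine B assay, tested at 10 uM (a lower number here means less inhibition, a higher number more inhibition at the concentration tested (going by the name of the read-out)), where compound 2 gives 92.3%. Within the data shown here, its only measured neighbour, compound 1 `CN1CCN(c2ccc(C3=NN(C(=O)CCCl)C(c4ccc(N(C)C)cc4)C3)cc2)CC1`, carries a (2-chloroethyl)carbonyl on the amine nitrogen in the ring in place of the (4-fluorophenyl)sulfonyl, and in this assay compound 1 gives 1.7%. Among the measured compounds shown here, the single step in hand, a number 90.6 percentage points higher from compound 1 to compound 2 (beyond the scatter), concerns the group on that amine nitrogen and not the substituent on the aryl ring of the sulfonyl.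

Compound 3 `CN1CCN(c2ccc(C3=NN(S(=O)(=O)c4ccc(C#N)cc4)C(c4ccc(N(C)C)cc4)C3)cc2)CC1` differs from compound 2 by cyano in place of fluoro on an aromatic carbon. For the measured compounds named here, no measured step bears on this exchange; the shared core and the arylsulfonyl linkage that accompanied the high number of compound 2 are both kept. With nothing in the data pointing to a loss, the number of compound 3 in this assay is expected to remain high, the expected step being a number 6.3 percentage points lower from compound 2 to compound 3 (within the scatter), which lies within the usual scatter. Compound 3 is accordingly estimated at 86%, with a range from 60% to 98%.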

Compound 3, a percentage reported as inhibition, at one concentration (the size of the read-out at that concentration, not a potency): 99.8%
The estimate for compound 3 lay 13.8 percentage points below the measured number; the measured number lies above the stated range.
By their numbers in this assay, from the lowest: compound 1; then compounds 2 and 3 (each within the scatter of the next).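

In this assay, the exchange on the aromatic carbon para to a large group comes to a number 7.5 percentage points higher from compound 2 to compound 3 (within the scatter), so fluoro and cyano cannot be told apart at this place at the concentration tested, and the high number of compound 2 is not tied to fluoro alone. The large step on the amine nitrogen in the ring now stands with a second arylsulfonyl, as a number 98.1 percentage points higher from compound 1 to compound 3 (beyond the scatter) shows the (4-cyanophenyl)sulfonyl, like the (4-fluorophenyl)sulfonyl, far from the (2-chloroethyl)carbonyl of compound 1. Nothing measured alongside these numbers bears on why the two substituents read alike or why the sulfonyl compounds stand so far from compound 1.

Still open, on these data alone, is whether an amine, a carboxylic acid or a methoxy at this place on the ring would keep the number as high, and whether a plain phenylsulfonyl or a methylsulfonyl on the ring nitrogen would do the same. The read-out is taken at one concentration and is not a potency, so it leaves open whether compound 2 and compound 3 would separate at lower concentrations.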